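This account rests on a few compounds, and the source may have more. Where it says the series, first, only, none or still open, it means among the compounds named here.

The series is read in a functional assay on A549 cells (Homo sapiens) for antiproliferative activity, read by MTT assay, with a stated time of 48 h (a higher number here means a weaker inhibitor, a lower number a stronger inhibitor), and has so far given no number. Compound 1 (`C/C(=C\CC/C(C)=C/CC[C@@H]1[C@@]2(C)CCC(=O)C(C)(C)[C@H]2CC[C@@]1(C)O)CC/C=C(\C)C(=O)OCc1cn(-c2ccccc2Br)nn1`) gives > 150000 nM and this is a limit of the assay. Compound 2 (`C/C(=C\CC/C(C)=C/CC[C@@H]1[C@@]2(C)CCC(=O)C(C)(C)[C@H]2CC[C@@]1(C)O)CC/C=C(\C)C(=O)OCc1cn(-c2cccc(Br)c2)nn1`) gives > 150000 nM and this too is a limit. Compound 3 (`C/C(=C\CC/C(C)=C/CC[C@@H]1[C@@]2(C)CCC(=O)C(C)(C)[C@H]2CC[C@@]1(C)O)CC/C=C(\C)C(=O)OCc1cn(-c2ccccc2)nn1`), with the plain phenyl group, gives > 150000 nM and this is again a limit. Compound 3 therefore has no number of its own and stands with the other two at the limit of > 150000 nM in this assay, at which 3 of the 3 values shown sit, in the record.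

Compound 4 (`C/C(=C\CC/C(C)=C/CC[C@@H]1[C@@]2(C)CCC(=O)C(C)(C)[C@H]2CC[C@@]1(C)O)CC/C=C(\C)C(=O)OCc1cn(-c2ccc(Cl)cc2)nn1`) is still to be measured. It has chloro in place of hydrogen on an aromatic carbon, para to a large group: chloro in place of hydrogen on an aromatic carbon.

The nearest measured changes are hydrogen in place of bromo on an aromatic carbon, seen in a step that the two limits leave unreadable from compound 1 to compound 3 and a step that the two limits leave unreadable from compound 2 to compound 3. Moving the bromo gives a step that the two limits leave unreadable from compound 1 to compound 2 as well. Within the data shown here, none of these steps has a readable size, and no chloro compound has been measured yet. With no halogen change having produced a number, no shift beyond the scatter is expected in either direction in this assay. The estimated step is a number no higher from compound 3 to compound 4 (the limit leaves the size open) and it rests on limits alone.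

The estimate for compound 4 is 150000 nM with an expected range from 60000 nM to 300000 nM and the assay will most likely report only a limit again.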

Compound 4, half-maximal inhibitory concentration: > 150000 nM
Compound 4 gave a limit, no number; the forecaster's own chance of this, stated with the estimate: 80%; the middle value sits exactly at the limit.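

In this assay compound 4 gives > 150000 nM, which is a limit and not a number. The steps to compound 4 from compound 1, compound 2 and compound 3 therefore cannot be read, as all four compounds stand at the same limit: the limit of > 150000 nM in this assay, at which 4 of the 4 values shown sit.

The compounds shown leave open whether any change on the phenyl group gives a measurable value in this assay.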